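Working notes: from compound 3 to compound 4

The compounds below may be only part of what the source reports. "The series", "measured", "known", "first", "only" and "open" are said of these compounds alone.

Measured in a functional assay on KYSE-450 cells (Homo sapiens) for inhibition, read by MTT assay, with a stated time of 48 h (on this read-out lower numbers stand for stronger inhibition and higher numbers for weaker inhibition), as follows
- compound 1 `CCC/C=C/C(=O)N(Cc1ccc(OC)c(O)c1)c1cc(OC)c(OC)c(OC)c1` gives 57 nM
- compound 2 `COc1ccc(CN(C(=O)CO)c2cc(OC)c(OC)c(OC)c2)cc1O` gives 370 nM
- compound 3 `COc1ccc(CN(C(=O)CCCl)c2cc(OC)c(OC)c(OC)c2)cc1O` gives 110 nM

Two steps fix where compound 3 stands among the three numbers: a 1.9-fold higher number from compound 1 to compound 3 (0.29 log units; within the scatter) and a 3.4-fold lower number from compound 2 to compound 3 (0.53 log units; beyond the scatter) in the same read-out. The next structure is compound 4 `COc1ccc(CN(C(=O)C[Se]C#N)c2cc(OC)c(OC)c(OC)c2)cc1O` with the change a group of 3 heavy atoms (1 carbon, 1 nitrogen, 1 selenium; no ring) in place of a group of 2 heavy atoms (1 carbon, 1 chlorine; no ring), on a saturated chain carbon bound to a carbonyl carbon on a saturated chain carbon bound to a carbonyl carbon. The nearest evidence is the modest step at that same place, a 3.4-fold lower number from compound 2 to compound 3 (0.53 log units; beyond the scatter) again. The largest measured change on a carbonyl carbon is a 6.5-fold higher number from compound 1 to compound 2 (0.81 log units; beyond the scatter) and it is also modest. Going by the values given here, no measured compound carries selenium or a triple bond, and the data give no direction for this change. In this assay no step beyond the scatter is therefore expected. The estimated step is a 1.4-fold lower number from compound 3 to compound 4 (0.14 log units; within the scatter) with wide uncertainty. Compound 4 is estimated at 80 nM with an expected range from 25 nM to 260 nM in this read-out.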

Compound 4, half-maximal inhibitory concentration: 280 nM
Compound 4: the middle estimate sits 3.5-fold (0.54 log units) below what was measured; measured number above the stated range.
By their numbers in this assay, from the lowest: compounds 1 and 3 (each within the scatter of the next); then compounds 4 and 2 (each within the scatter of the next).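

At this place, on a saturated chain carbon bound to a carbonyl carbon, the group holding selenium and a triple bond does not match chloromethyl: this assay shows a 2.5-fold higher number from compound 3 to compound 4 (0.41 log units; beyond the scatter) in a step that gives this position its first measured penalty for a larger group. Against the oxygen-bearing side chain there is a 1.3-fold lower number from compound 2 to compound 4 (0.12 log units; within the scatter) and no separation, while replacement of the whole pent-1-en-1-yl chain on a carbonyl carbon gives a 4.9-fold higher number from compound 1 to compound 4 (0.69 log units; beyond the scatter) as the cost of that exchange. Nothing on hand explains the weaker inhibition by compound 4 relative to compound 3.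

Whether the selenium or the nitrile accounts for this step remains open, and a thiocyanate at the same place would separate the two. Going by these compounds, how an amine, a carboxylic acid or a longer chain would read at this position also remains open.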